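Shortening the Amine Chain and Moving the Halogen

A few compounds are considered here, and "the series" means these few. Any claim that something is new, unique, unknown or untested is made for them only; others in the source may bear on it.

Measured compounds:
compound 1, `O=S(=O)(NCCCCNCc1ccc(Br)cc1)c1cc(C(F)(F)F)cc(C(F)(F)F)c1`, 2000 nM
compound 2, `O=S(=O)(NCCCNCc1ccc(Cl)c(C(F)(F)F)c1)c1cc(C(F)(F)F)cc(C(F)(F)F)c1`, 3000 nM
compound 3, `O=S(=O)(NCCCNCC1COc2ccccc2O1)c1cc(C(F)(F)F)cc(C(F)(F)F)c1`, 2700 nM

All three share the same sulfonamide core and were tested in a functional assay on HPAC cells (Homo sapiens) for inhibition, read by MTT assay, with a stated time of 72 h; a lower number here means a stronger inhibitor of growth, a higher number a weaker inhibitor of growth. Compound 1 gives the lowest of the three numbers, yet its nearest neighbour compound 3 and the furthest, compound 2, both lie within the usual scatter of it, so no order among the three can be claimed.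

Compound 4, `O=S(=O)(NCCCNCc1cccc(Cl)c1)c1cc(C(F)(F)F)cc(C(F)(F)F)c1`, differs from compound 1 in one place: (3-chlorobenzyl)amino in place of ((4-bromobenzyl)amino)methyl on a saturated chain carbon, three bonds along the chain from a sulfonamide nitrogen.

Within the data shown here, only one measured step bears on this: the swap of the aromatic group on the amine side, a 1.1-fold lower number from compound 2 to compound 3 (0.05 log units; within the scatter). That swap of the group on the amine side barely moved the number. Among the measured compounds shown here, no measured pair speaks to the shorter chain between the amine nitrogen and the sulfonamide nitrogen, so that part of the change is uncharted. On the evidence at hand the expected step is small, a 1.3-fold higher number from compound 1 to compound 4 (0.10 log units; within the scatter), with no clear direction beyond the scatter. Compound 4 is therefore estimated at 2500 nM, with a likely range from 1200 nM to 5500 nM.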

Compound 4, concentration for 50% growth inhibition: 2700 nM
The estimate for compound 4 lay 1.1-fold (0.03 log units) below the measured number, and the stated range covers the measured number.
By their numbers in this assay, from the lowest: compounds 1, 3, 4 and 2 (each within the scatter of the next).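

In this assay the change from ((4-bromobenzyl)amino)methyl to (3-chlorobenzyl)amino, on a saturated chain carbon three bonds along the chain from a sulfonamide nitrogen, gives (a 1.4-fold higher number from compound 1 to compound 4 (0.13 log units; within the scatter)). On the saturated chain carbon bound to an amine nitrogen, 3-chlorophenyl in place of 2,3-dihydro-1,4-benzodioxin-2-yl gives (no change at the digits printed from compound 3 to compound 4 (within the scatter)), and 3-chlorophenyl in place of 4-chloro-3-(trifluoromethyl)phenyl gives (a 1.1-fold lower number from compound 2 to compound 4 (0.05 log units; within the scatter)). Compound 4 therefore adds a third group on that carbon, and the numbers for compounds 2, 3 and 4 all stay within the scatter of one another.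

As far as these compounds go, the step from compound 1 alters the chain and the halogen together, so their separate contributions remain open, as does the outcome of placing a carboxylic acid on the aromatic ring. Nothing measured here explains why these numbers lie so close together.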